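Same Halogen Swap, Second Core: Predicting Compound 4

The source may report more compounds than this note shows. Statements on the series, on what has been measured and on what is new or still open speak of the compounds shown alone.

The measured compounds:
compound 1 `Nc1ccc(/C=C2\SC(=O)N(Cc3cccc(Cl)c3)C2=O)cc1`: 10000 nM
compound 2 `Nc1ccc(/C=C2\SC(=O)N(Cc3ccc(F)cc3)C2=O)cc1`: 36000 nM
compound 3 `C=C(Br)C(=O)Nc1ccc(/C=C2\SC(=O)N(Cc3ccc(F)cc3)C2=O)cc1`: 4600 nM

In a functional assay on FM3A cells (Mus musculus) for cytotoxicity, read by cell counting, with a stated time of 2 days (a lower number here means a stronger inhibitor, a higher number a weaker inhibitor), compound 2 gives 36000 nM. Compound 1 differs from compound 2 by 3-chlorophenyl in place of 4-fluorophenyl on a saturated chain carbon bound to an amide-type nitrogen in a ring, a change that made a 3.6-fold lower number from compound 2 to compound 1 (0.56 log units; beyond the scatter). Compound 3 differs from compound 2 by (1-bromoethenyl)carbonyl in place of hydrogen on a nitrogen on an aromatic ring, which made a 7.8-fold lower number from compound 2 to compound 3 (0.89 log units; beyond the scatter); compound 3 is the most potent of the three, its steps to both others lying beyond the scatter.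

Compound 4 `C=C(Br)C(=O)Nc1ccc(/C=C2\SC(=O)N(Cc3cccc(Cl)c3)C2=O)cc1` has not yet been measured. It differs from compound 3 by 3-chlorophenyl in place of 4-fluorophenyl on a saturated chain carbon bound to an amide-type nitrogen in a ring, the same change as in the pair of compound 2 and compound 1, at the same place, but carried out on the core of compound 3. The expectation rests on a 3.6-fold lower number from compound 2 to compound 1 (0.56 log units; beyond the scatter). Compound 3 to compound 4 is therefore expected to give a 3.1-fold lower number from compound 3 to compound 4 (0.49 log units; beyond the scatter), allowing that the gain may be somewhat smaller on this core. Compound 4 is estimated at 1500 nM in this assay, most likely between 500 nM and 4500 nM.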

Compound 4, half-maximal inhibitory concentration: 6100 nM
For compound 4 the middle estimate is 4.1-fold (0.61 log units) below the measured one; the measured number lies above the stated range.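

In this assay, the change from 4-fluorophenyl to 3-chlorophenyl brings no gain that stands out from the scatter on the core of compound 3, giving a 1.3-fold higher number from compound 3 to compound 4 (0.12 log units; within the scatter), so the gain seen on the core of compound 2 did not carry over: the same change on two cores in this assay, a 3.6-fold lower number (0.56 log units; beyond the scatter) from compound 2 to compound 1 and a 1.3-fold higher number (0.12 log units; within the scatter) from compound 3 to compound 4, 4.8-fold (0.68 log units) apart, beyond the scatter of two such steps. Seen from the other side, adding the (1-bromoethenyl)carbonyl group gives a 1.6-fold lower number from compound 1 to compound 4 (0.21 log units; within the scatter), so its gain also depends on the benzyl group present: the same change on two cores in this assay, a 7.8-fold lower number (0.89 log units; beyond the scatter) from compound 2 to compound 3 and a 1.6-fold lower number (0.21 log units; within the scatter) from compound 1 to compound 4, 4.8-fold (0.68 log units) apart, beyond the scatter of two such steps. The two changes therefore do not simply add up in these four compounds, but this does not show why, and it cannot predict how other changes would carry over.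

From the compounds shown here alone, it remains open whether an unsubstituted benzyl group would follow compound 1 or compound 2 on these cores. Going by these compounds, it also remains open whether a plain acetyl group on the nitrogen would match the (1-bromoethenyl)carbonyl group.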